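The source may hold more compounds than are shown below. What is called first, only, known or untested is meant among the compounds shown, and "the series" means these compounds.

Measured so far:
- Compound 1, `CC(C)N1CCN(Cc2csc(N)c2C(=O)c2ccc(Cl)cc2)CC1`, gives -7.4% in a functional assay on CHO cells with adenosine receptor A1 (Homo sapiens) as the target, read by cAMP accumulation and immunoassay, with a stated time of 6 min, tested at 10 uM; a higher number here means a weaker effect of the compound at the concentration tested, a lower number a stronger effect.
- Compound 2, `Nc1scc(CN2CCN(c3ccc(Cl)cc3Cl)CC2)c1C(=O)c1ccc(Cl)cc1`, gives -74% in this assay.

Compound 2 stands lowest of the two numbers, and its nearest neighbour is compound 1, which lies higher by the step of a number 66.6 percentage points lower from compound 1 to compound 2 (beyond the scatter). That single step comes from a 2,4-dichlorophenyl in place of isopropyl on an amine nitrogen in a ring, a large change of the whole group.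

Compound 3, `Nc1scc(CN2CCN(c3ccc(Cl)cc3F)CC2)c1C(=O)c1ccc(Cl)cc1`, has not been measured. It differs from compound 2 in one place: fluoro in place of chloro on an aromatic carbon. Within the data shown here, no measured step covers a swap of one halogen for another on this ring; the only known step, from compound 1 to compound 2, concerns a different and much larger change, so it offers only a loose guide.

The expectation for compound 3 is therefore a step of a number 14 percentage points higher from compound 2 to compound 3 (beyond the scatter), small and possibly within the scatter, with compound 3 estimated at -60%, with a range from -85% to -30%.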

Compound 3, a percentage reported as activity, at one concentration (the size of the read-out at that concentration, not a potency): -81%
For compound 3 the middle estimate is 21 percentage points above the measured one, and the stated range covers the measured number.
By their numbers in this assay, from the lowest: compounds 3 and 2 (each within the scatter of the next); then compound 1.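

At the place ortho to a large group, fluoro in place of chloro gives no change beyond the scatter in this assay (a number 7 percentage points lower from compound 2 to compound 3 (within the scatter)), so this position accepts either halogen in these two compounds. The large gain over the isopropyl group also holds with the 4-chloro-2-fluorophenyl group (a number 73.6 percentage points lower from compound 1 to compound 3 (beyond the scatter)), so within this set it does not depend on having chloro at this place. Nothing at hand explains why the two halogens read alike here.

From the compounds shown here alone, whether a halogen is needed at this place at all remains open, and a methoxy group, a nitrile or a plain hydrogen there would test that. Going by these compounds, the other chloro group stays the same in compound 2 and compound 3, so its own contribution also remains unknown.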